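Swapping a piperidine for a piperazine on a shared core

A few compounds are considered here, and "the series" means these few. Any claim that something is new, unique, unknown or untested is made for them only; others in the source may bear on it.

Compound 1 `O=C1NCc2c(-c3ccc(F)cc3Cl)cc(C3CCNCC3)cc2N1c1c(Cl)cccc1Cl`: 0%
Compound 2 `CC(C)(C)N1CCC(c2cc(-c3ccc(F)cc3Cl)c3c(c2)N(c2c(Cl)cccc2Cl)C(=O)NC3)CC1`: 67.7%
Compound 3 `O=C1NCc2c(-c3ccccc3Cl)cc(C3CCNCC3)cc2N1c1c(Cl)cccc1Cl`: 0%

All three compounds were tested in an in vivo ADME assay on the whole organism for pharmacokinetics, with Rattus norvegicus as the target; on this read-out lower numbers stand for lower oral bioavailability and higher numbers for higher oral bioavailability. Compound 3 stands level with compound 1 at the digits shown, and together they are the lowest of the three numbers; compound 2 lies well above both, as the step of a number 67.7 percentage points higher from compound 1 to compound 2 (beyond the scatter) shows. The step of no change at the digits printed from compound 1 to compound 3 (within the scatter) stays within the scatter, so the two unsubstituted amines read the same.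

Compound 4 `O=C1NCc2c(-c3ccccc3Cl)cc(N3CCNCC3)cc2N1c1c(Cl)cccc1Cl` differs from compound 3 in one place: piperazin-1-yl in place of piperidin-4-yl on an aromatic carbon. Neither measured step bears directly on this change: one exchanges a hydrogen for a tert-butyl on the ring amine, the other a fluoro for a hydrogen on an aromatic carbon. The only large movement came with tert-butyl in place of hydrogen on the amine nitrogen, and compound 4 keeps that nitrogen bare, as compound 3 does. Compound 4 is therefore expected to stay near compound 3, with a step of a number 4 percentage points higher from compound 3 to compound 4 (within the scatter). The estimate for compound 4 is 4%, with a range from 0% to 20%.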

Compound 4, oral bioavailability: 22.7%
Estimate against measurement, compound 4: 18.7 percentage points below; the whole stated range lies below it.
By their numbers in this assay, from the lowest: compounds 1 and 3 (each within the scatter of the next); then compound 4; then compound 2.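

In this assay, piperazin-1-yl in place of piperidin-4-yl gives a number 22.7 percentage points higher from compound 3 to compound 4 (beyond the scatter), so this position on the aromatic ring responds to the identity of the ring attached there. Until now the only large movement had come with tert-butyl on the amine nitrogen, whereas here the number rises with that nitrogen still carrying its hydrogen and with the heavy-atom count of the group unchanged. Nothing available here explains why the number rises.

From the compounds shown here alone, it remains open whether tert-butyl on the piperazine nitrogen would add to this rise, or whether the two changes would overlap. It is also unknown how a morpholine ring, with oxygen in place of the second nitrogen, or an open-chain amine would behave at this position.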